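The compounds below may be only part of what the source reports. "The series", "measured", "known", "first", "only" and "open" are said of these compounds alone.

Working notes on the thienopyrimidine-ether amide series, read in a functional assay on A549 cells (Homo sapiens) for cytotoxicity, read by MTT assay, with a stated time of 72 h; a higher number here means a weaker inhibitor, a lower number a stronger inhibitor.

Compound 1 `Cc1ccc(-n2nc(C(=O)Nc3ccc(Oc4ncnc5ccsc45)cc3)c(C)cc2=O)cc1` gives 11500 nM. Compound 2 `Cc1ccc(-n2nc(C(=O)Nc3ccc(Oc4ncnc5ccsc45)cc3)c(C)cc2=O)c(C)c1` gives 16400 nM. The step of a 1.4-fold higher number from compound 1 to compound 2 (0.15 log units; within the scatter) is methyl in place of hydrogen on an aromatic carbon, a change that does not move the number beyond the scatter.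

Compound 3 `O=C(Nc1ccc(Oc2ncnc3ccsc23)c(F)c1)c1nn(-c2ccccc2)ccc1=O` gives 19700 nM. Compound 3 and compound 1 differ in more than one place; the difference between the two cores is not broken down here. The three measured numbers lie within the scatter of one another, so no order among them is read.

Compound 4 `Cc1ccc(-n2ccc(=O)c(C(=O)Nc3ccc(Oc4ncnc5ccsc45)c(F)c3)n2)cc1` is not yet measured. It differs from compound 3 by methyl in place of hydrogen on an aromatic carbon. This is the same kind of change as from compound 1 to compound 2, not the same: there the methyl enters ortho to a large group and meta to a methyl group; here it enters para to a large group.

For compound 4 a step of a 1.1-fold higher number from compound 3 to compound 4 (0.05 log units; within the scatter) is expected, resting on the earlier step of a 1.4-fold higher number from compound 1 to compound 2 (0.15 log units; within the scatter), which stayed within the scatter. Compound 4 is estimated at 22000 nM, between 9000 nM and 50000 nM.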

Compound 4, half-maximal inhibitory concentration: 11600 nM
Compound 4: middle estimate off by 1.9-fold (0.28 log units), on the high side; measured number inside the range.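

In this assay, methyl in place of hydrogen on the phenyl ring, phenyl to 4-methylphenyl, gives a 1.7-fold lower number from compound 3 to compound 4 (0.23 log units; within the scatter), so this step, like the earlier one, does not move the number beyond the scatter. Set beside that earlier step, the same change shows no difference between the two cores: the same change on two cores in this assay, a 1.4-fold higher number (0.15 log units; within the scatter) from compound 1 to compound 2 and a 1.7-fold lower number (0.23 log units; within the scatter) from compound 3 to compound 4, 2.4-fold (0.38 log units) apart, within the scatter of two such steps. Within the data shown here, this shows only that the methyl change stayed within the scatter on both cores, and it does not show that the change is neutral in general, as there are just two pairs and the methyl enters at a different place in each.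

The compounds shown leave open whether any group on this phenyl ring, such as an amine, a carboxylic acid or a longer alkyl chain in place of the methyl, would move the number beyond the scatter. Among these compounds, they also leave open how far the differences between the two cores bear on the number, as no single-place step connects one core to the other.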